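Cytotoxicity Limits Across Three Analogues and One Untested

A few compounds are considered here, and "the series" means these few. Any claim that something is new, unique, unknown or untested is made for them only; others in the source may bear on it.

Compound 1 `O=C(NCc1ccccc1)Nc1cc2nc(C3CCCCC3)[nH]c2cc1N1CCCC1`: > 100 ug/mL
Compound 2 `COc1ccc(C(=O)Nc2cc3nc(C4CCCCC4)[nH]c3cc2N2CCCC2)cc1`: > 100 ug/mL
Compound 3 `O=C(CCc1ccccc1)Nc1cc2nc(C3CCCCC3)[nH]c2cc1N1CCCC1`: > 100 ug/mL

In an ADME assay on Vero cells (Chlorocebus sabaeus) for cytotoxicity, read by resazurin assay, with a stated time of 3 days (on this read-out lower numbers stand for stronger inhibition and higher numbers for weaker inhibition), every value recorded so far is a limit of the assay and not a number. Compound 3 sits at that limit, since > 100 ug/mL is a limit. The three measured steps, a step that the two limits leave unreadable from compound 1 to compound 2, a step that the two limits leave unreadable from compound 1 to compound 3 and a step that the two limits leave unreadable from compound 2 to compound 3, cannot be read in size, because the limit of > 100 ug/mL in this assay, at which 3 of the 3 values shown sit, holds all of them. Compound 4 `O=C(Nc1cc2nc(C3CCCCC3)[nH]c2cc1N1CCCC1)c1ccc(Br)cc1` differs from compound 3 by 4-bromophenyl in place of phenethyl on a carbonyl carbon. For the measured compounds named here, no measured step bears readably on this change. Compound 4 is therefore expected to remain at the limit as well, estimated near 100 ug/mL with a range from 50 ug/mL to 200 ug/mL. The expected step is a number no higher from compound 3 to compound 4 (the limit leaves the size open), nothing beyond the scatter.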

Compound 4, half-maximal inhibitory concentration: > 100 ug/mL
Compound 4: only a limit was reported (the forecaster's own chance of this, stated with the estimate: 85%); the middle value sits exactly at the limit.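

For the compounds shown here, compound 4 gives > 100 ug/mL, which is a limit of the assay and not a number, so no step from compound 1, compound 2 or compound 3 to compound 4 can be read: the limit of > 100 ug/mL in this assay, at which 4 of the 4 values shown sit. The compounds shown leave open how far each one's actual value lies from that limit, and whether any of these changes alters cytotoxicity at all.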